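The source may hold more compounds than are shown below. What is called first, only, known or untested is meant among the compounds shown, and "the series" means these compounds.

Measured so far:
Compound 1, `N#C/C(=C\c1ccc([N+](=O)[O-])cc1)C(=O)c1c[nH]c2ccccc12`, gives 42000 nM in a functional assay on SW480 cells (Homo sapiens) for inhibition, read by MTT assay, with a stated time of 72 h; on this read-out higher numbers stand for weaker inhibition of growth and lower numbers for stronger inhibition of growth.
Compound 2, `N#C/C(=C\c1ccc[nH]1)C(=O)NCc1ccc(Cl)c(Cl)c1`, is recorded in this assay only as a limit, > 50000 nM, not as a number.
Compound 3, `COc1ccc(CNC(=O)/C(C#N)=C/c2ccc(C)o2)cc1`, gives 29000 nM in this assay.

Among the two compounds with a numerical value, compound 3 has the lower number, but its nearest neighbour is compound 1, and that gap lies within the scatter of repeated measurements, so no order between them can be claimed. Compound 4, `COc1ccc(CNC(=O)/C(C#N)=C/c2ccoc2)cc1`, has not yet been measured. It differs from compound 3 in one place: furan-3-yl in place of 5-methylfuran-2-yl on a double-bonded chain carbon bound to a double-bonded chain carbon. Going by the values given here, no step between measured compounds touches the group on that chain carbon, so the size of the change cannot be read from the data. Compound 4 is expected to sit close to compound 3, with a step of a 1.4-fold higher number from compound 3 to compound 4 (0.14 log units; within the scatter) that may not exceed the scatter, leaning towards a weaker result. The estimate for compound 4 is 40000 nM, between 18000 nM and 100000 nM.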

Compound 4, concentration for 50% growth inhibition: 8000 nM
For compound 4 the middle estimate is 5.0-fold (0.70 log units) above the measured one; measured number below the stated range.
By their numbers in this assay, from the lowest: compound 4; then compounds 3 and 1 (each within the scatter of the next). At a limit, above all of these: compound 2.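

In this assay, furan-3-yl in place of 5-methylfuran-2-yl on a double-bonded chain carbon bound to a double-bonded chain carbon brings a 3.6-fold lower number from compound 3 to compound 4 (0.56 log units; beyond the scatter) and so shows that the group at this place can shift the result. The step combines the loss of the methyl with the move from a furan-2-yl to a furan-3-yl group, and the compounds shown cannot divide it between those two changes. No measurement shown here bears on the cause of this step.

On these data alone, it remains open how unsubstituted furan-2-yl would compare at this place. As far as these compounds go, the result of a thiophene or phenyl group there is also open.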